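The source may report more compounds than this note shows. Statements on the series, on what has been measured and on what is new or still open speak of the compounds shown alone.

In an ADME assay on the whole organism (muscle tissue) for activation, with Mus musculus as the target, in the rotarod test, with a stated time of 30 min (a lower number here means that less compound is needed, a higher number that more compound is needed for the effect), compound 1 `N#Cc1ccc(-c2ccc(/C=N/N3C(=O)NC(=O)C3O)o2)cc1` gives 96 mg/kg. Compound 2 `Nc1ccc(-c2ccc(/C=N/N3C(=O)NC(=O)C3O)o2)cc1` gives > 1000 mg/kg, and this is a limit of the assay and not a number. Compound 2 therefore has no exact position, and any comparison with it has an open end. Compound 3 `O=C1NC(=O)N(/N=C/c2ccc(-c3ccc(F)cc3)o2)C1O` keeps the shared core and carries fluoro in place of amino on an aromatic carbon, para to a large group: fluoro in place of amino on an aromatic carbon. Among the measured compounds shown here, only one measured step bears on this place, the change of cyano to amino that gives an at least 10-fold higher number from compound 1 to compound 2 (1.01 log units; beyond the scatter). From the compounds shown here alone, on that large step, losing the amino group of compound 2 is expected to bring a clearly lower number in this assay, although fluoro itself is untested here. The expected change is an at least 6.6-fold lower number from compound 2 to compound 3 (0.82 log units; beyond the scatter). For compound 3 the estimated value is 150 mg/kg, with an expected range from 45 mg/kg to 500 mg/kg.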

Compound 3, dose for half-maximal effect: 240 mg/kg
Beside the measured number, compound 3's estimate is 1.6-fold (0.20 log units) below it, within the range that was stated.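

Fluoro in place of amino on the aromatic carbon gives an at least 4.1-fold lower number from compound 2 to compound 3 (0.61 log units; beyond the scatter), so in this assay the high number of compound 2 does not extend to every replacement of cyano at this place. Fluoro in place of cyano still gives a 2.5-fold higher number from compound 1 to compound 3 (0.40 log units; beyond the scatter), which shows that the two groups other than amino also differ from each other and that compound 1 has the lowest number of the three. The true size of the step from amino to fluoro stays open, since compound 2 stands at a limit of the assay and not at a number: the limit of > 1000 mg/kg in this assay, at which 1 of the 3 values shown sits.

The compounds shown leave open how other groups at this place, such as a methoxy group, a chlorine atom or a carboxylic acid, would fall relative to these three. They also say nothing about changes elsewhere on the shared core.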